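From 3-fluorophenyl to 1-methylpyrrolidin-2-yl on a carbonyl carbon

The source may hold more compounds than are shown below. What is called first, only, known or untested is meant among the compounds shown, and "the series" means these compounds.

Of the compounds shown here, three sharing one core have been measured in a physicochemical assay for solubility, read by LC-MS, in phosphate buffer, with a stated time of 24 h, at pH 6.8; a lower number here means a less soluble compound, a higher number a more soluble compound. Compound 1 `C[C@H](NC(=O)c1cccc(F)c1)c1ccc(NC(=O)N2CC(c3cccnc3)C2)cc1` gives 11000 nM, compound 2 `C[C@H](NC(=O)c1cccc(F)c1)c1ccc(NC(=O)N2CC(c3ccc(N)nc3)C2)cc1` gives 32000 nM, and compound 3 `C[C@H](NC(=O)c1cccc(F)c1)c1ccc(NC(=O)N2CC(c3cncc(N)c3)C2)cc1` gives 17000 nM. Compound 3 thus stands within the scatter of both others, as the steps show: a 1.5-fold higher number from compound 1 to compound 3 (0.19 log units; within the scatter) and a 1.9-fold lower number from compound 2 to compound 3 (0.27 log units; within the scatter). Within the data shown here, only one step goes beyond the scatter, and modestly: a 2.9-fold higher number from compound 1 to compound 2 (0.46 log units; beyond the scatter).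

Compound 4 `C[C@H](NC(=O)[C@@H]1CCCN1C)c1ccc(NC(=O)N2CC(c3cncc(N)c3)C2)cc1` carries 1-methylpyrrolidin-2-yl in place of 3-fluorophenyl on a carbonyl carbon. Among the measured compounds shown here, none of the measured steps touches this place, so they give no direct measure of the size of this change. The expectation rests on the structural change alone, in which the six-membered aromatic ring of carbon only leaves and a non-aromatic ring with a hydrogen-bond acceptor enters. A higher number, clearly beyond the scatter, is expected. The expected step is a 5.9-fold higher number from compound 3 to compound 4 (0.77 log units; beyond the scatter). Compound 4 is estimated at 100000 nM, with an expected range of 35000 nM to 300000 nM.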

Compound 4, solubility: 820000 nM
For compound 4 the middle estimate is 8.2-fold (0.91 log units) below the measured one; the measured number lies above the stated range.
By their numbers in this assay, from the lowest: compounds 1, 3 and 2 (each within the scatter of the next, the first and the last beyond it); then compound 4.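

In this assay, the carbonyl carbon proves to be a highly responsive place: 1-methylpyrrolidin-2-yl in place of 3-fluorophenyl gives a 48-fold higher number from compound 3 to compound 4 (1.68 log units; beyond the scatter). The earlier compounds shown here varied only the amino group and its place on the aminopyridine, and their largest step, a 2.9-fold higher number from compound 1 to compound 2 (0.46 log units; beyond the scatter), is far smaller, so this single change stands apart among the four compounds. No measurement at hand accounts for the size of this step.

The compounds shown leave open which part of the exchange carries the step, a question that a cyclohexyl group or a pyrrolidin-2-yl group lacking the methyl on nitrogen, placed on the same carbonyl carbon, could help to settle. They also leave open whether 1-methylpyrrolidin-2-yl gives a step of similar size alongside the 6-aminopyridin-3-yl group of compound 2.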